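Chloro to methyl swap on the benzoyl ring, second core

This account rests on a few compounds, and the source may have more. Where it says the series, first, only, none or still open, it means among the compounds named here.

Compound 1 `N#Cc1c(Cl)c(Cl)c(C(C(=O)c2ccc(Cl)cc2)=C2NCCN2)c(C#N)c1Cl` and compound 3 `Cc1ccc(C(=O)C(=C2NCCN2)c2c(Cl)c(Cl)c(C#N)c(Cl)c2C#N)cc1` share one core; compound 2 `N#Cc1c(F)c(Cl)c(C(C(=O)c2ccc(Cl)cc2)=C2NCCN2)c(C#N)c1F` and compound 4 `Cc1ccc(C(=O)C(=C2NCCN2)c2c(Cl)c(F)c(C#N)c(F)c2C#N)cc1` share a second one. The difference between the two cores is not broken down here. In a functional assay on SK-OV-3 cells (Homo sapiens) for antiproliferative activity, read by MTT assay (on this read-out higher numbers stand for weaker inhibition and lower numbers for stronger inhibition), compound 1 gives 1.6 ug/mL. In the same assay compound 3 gives 9.2 ug/mL, and compound 2 gives 8.6 ug/mL. The change from compound 1 to compound 3 is methyl in place of chloro on an aromatic carbon, and the measured step is a 5.8-fold higher number from compound 1 to compound 3 (0.76 log units; beyond the scatter). The change from compound 2 to compound 4 is methyl in place of chloro on an aromatic carbon; the two place descriptions read the same word for word, so this is the same change made on the second core. Compound 4 has not been measured in this assay. Among the compounds with values here, the expected step is a 4.7-fold higher number from compound 2 to compound 4 (0.67 log units; beyond the scatter), which rests on the single earlier instance a 5.8-fold higher number from compound 1 to compound 3 (0.76 log units; beyond the scatter), as no other pair shows the change. The value for compound 4 is estimated at 40 ug/mL, with a plausible range from 15 ug/mL to 120 ug/mL.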

Compound 4, half-maximal inhibitory concentration: 6.7 ug/mL
Estimate against measurement, compound 4: 6.0-fold (0.78 log units) above; measured number outside the range, below it.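

In this assay, the change from 4-chlorophenyl to 4-methylphenyl does not carry over from the core of compound 1 to the core of compound 2, as the new step is a 1.3-fold lower number from compound 2 to compound 4 (0.11 log units; within the scatter). The two instances of the same change, set side by side, disagree: the same change on two cores in this assay, a 5.8-fold higher number (0.76 log units; beyond the scatter) from compound 1 to compound 3 and a 1.3-fold lower number (0.11 log units; within the scatter) from compound 2 to compound 4, 7.4-fold (0.87 log units) apart, beyond the scatter of two such steps. This shows that, in these four compounds, the step measured on one core cannot be transferred to the other, but with a single pair per core it does not show which difference between the cores goes with the divergence, or how the change would behave on any further core.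

The compounds shown leave open whether other groups on the same aromatic carbon, such as an amine, a methoxy group or a carboxylic acid, would also separate the two cores. Also open, going by these compounds, is whether a longer chain in place of the methyl would follow the pattern of the core of compound 1 or that of the core of compound 2.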